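Moving the chlorine along the benzyl ring of a cathepsin S inhibitor

The compounds below may be only part of what the source reports. "The series", "measured", "known", "first", "only" and "open" are said of these compounds alone.

Measured compounds:
- compound 1, `CC(C)C[C@H](NC(=O)N1CCOCC1)C(=O)N[C@H](C#N)CCc1ccccc1`: 7 nM
- compound 2, `CC(C)C[C@H](NC(=O)N1CCOCC1)C(=O)N[C@H](C#N)COCc1ccccc1Cl`: 0.3 nM

Both were tested in an assay on isolated protein for displacement of a labelled ligand from cathepsin S (Homo sapiens), read by fluorescence; on this read-out higher numbers stand for weaker binding and lower numbers for tighter binding. Compound 2 gives the lowest of the two numbers; its nearest neighbour is compound 1, and the step of a 23-fold lower number from compound 1 to compound 2 (1.37 log units; beyond the scatter) is large and well beyond the scatter. Compound 3, `CC(C)C[C@H](NC(=O)N1CCOCC1)C(=O)N[C@H](C#N)COCc1cccc(Cl)c1`, has not yet been measured. It differs from compound 2 only in the placement of the chlorine: 3-chlorophenyl in place of 2-chlorophenyl on a saturated chain carbon bound to an oxygen on a saturated carbon. Within the data shown here, no measured step involves shifting a substituent from one position of this ring to another; the single step available, from compound 1 to compound 2, changed the whole side chain and so bears only loosely on this question. A much smaller movement of the number is therefore expected for compound 3, with no strong reason to favour either direction, a 2.0-fold higher number from compound 2 to compound 3 (0.30 log units; within the scatter). For compound 3 the expected value is 0.6 nM, within a range from 0.15 nM to 3 nM.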

Compound 3, dissociation constant: 0.5 nM
The estimate for compound 3 lay 1.2-fold (0.08 log units) above the measured number; the range from low to high includes it.
By their numbers in this assay, from the lowest: compounds 2 and 3 (each within the scatter of the next); then compound 1.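

In this assay, among these compounds, a 1.7-fold higher number from compound 2 to compound 3 (0.22 log units; within the scatter) shows that 3-chlorophenyl and 2-chlorophenyl cannot be told apart at this position, a comparison that the earlier compounds could not offer. The large step seen with the first chlorine placement also appears with the second, as a 14-fold lower number from compound 1 to compound 3 (1.15 log units; beyond the scatter) is again well beyond the scatter, so it does not depend on just one of these two placements. Nothing measured here gives a reason for either step.

Going by these compounds, the steps from compound 1 change the chain and add the chlorine together, so the share of each stays unknown; a plain benzyloxy side chain, with no chlorine on the ring, would separate them. Also open, on these data alone, is whether the ring tolerates other groups at these places, such as a methoxy group, a fluorine or a carboxylic acid.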